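A few compounds are considered here, and "the series" means these few. Any claim that something is new, unique, unknown or untested is made for them only; others in the source may bear on it.

In a functional assay on MCF7 cells (Homo sapiens) for inhibition, read by MTT assay, with a stated time of 2 days (on this read-out higher numbers stand for weaker inhibition and lower numbers for stronger inhibition), the measured compounds stand as follows

compound 1 `Oc1ccc(/C=C/c2cccc(O)c2)cc1` gives 23 ug/mL
compound 2 `COc1ccc(/C=C/c2cccc(O)c2)cc1` gives 21 ug/mL

Compound 1 and compound 2 lie within the scatter of each other, so these numbers set neither apart. Compound 3 (`COc1cccc(/C=C/c2ccc(O)cc2)c1`) is not yet measured and differs from compound 1 by methyl in place of hydrogen on an oxygen on an aromatic ring in this way: methyl in place of hydrogen on an oxygen on an aromatic ring. Among the measured compounds shown here, the one measured step of this kind, made on the other oxygen, is a 1.1-fold lower number from compound 1 to compound 2 (0.04 log units; within the scatter) and lies within the scatter. For the measured compounds named here, no measurement yet covers the oxygen changed in compound 3, so this support is thin. No step beyond the scatter is therefore expected in this assay here. Compound 3 is estimated at 22 ug/mL with an expected range from 10 ug/mL to 46 ug/mL in this read-out. This estimate means an expected 1.0-fold lower number from compound 1 to compound 3 (0.02 log units; within the scatter) and nothing larger.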

Compound 3, half-maximal inhibitory concentration: 21 ug/mL
Compound 3: middle estimate off by 1.0-fold (0.02 log units), on the high side; the range from low to high includes it.
By their numbers in this assay, from the lowest: compounds 2, 3 and 1 (each within the scatter of the next).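

In this assay, methyl in place of hydrogen on the other oxygen of compound 1 also leaves the number within the scatter, with a 1.1-fold lower number from compound 1 to compound 3 (0.04 log units; within the scatter) as the step. Hydroxy to methoxy has now been read on each of the two oxygens, the earlier case being a 1.1-fold lower number from compound 1 to compound 2 (0.04 log units; within the scatter) on the other ring, so in these compounds neither single change separates itself from compound 1 on this read-out. No independent evidence bears on this result.

Still open, as far as these compounds go, is whether methyl on both oxygens at once would keep the number within the scatter of compound 1. Also open, from the compounds shown here alone, is whether a longer chain on either oxygen, or an amine or a carboxylic acid in place of a hydroxy group, would produce a step beyond the scatter.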